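The compounds below may be only part of what the source reports. "The series", "measured", "known", "first", "only" and "open" are said of these compounds alone.

Measured compounds in an ADME assay on L6 cells (Rattus norvegicus) for cytotoxicity; a higher number here means a weaker inhibitor, a lower number a stronger inhibitor:
Compound 1, `c1ccc(Oc2ccc(-c3cc(N4CCNCC4)[nH]n3)cc2)cc1`: 18000 nM
Compound 2, `CSC(=CC(=O)c1ccc([N+](=O)[O-])cc1)SC`: 40500 nM
Compound 3, `CSC(=CC(=O)c1ccc(Oc2ccc([N+](=O)[O-])cc2)cc1)SC`: 156000 nM

Among these three, compound 1 gives the lowest number in this assay. Its nearest neighbour is compound 2, whose value lies above it by a margin beyond the scatter, and compound 3 stands furthest away, again beyond the scatter. Among the measured compounds shown here, compound 2 and compound 3 are built on a different core from compound 1, and no pair of measured compounds differs in a single place, so the set offers no direct single-point step to lean on.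

Compound 4, `CC(C)(C)OC(=O)N1CCN(c2cc(-c3ccc(Oc4ccccc4)cc3)n[nH]2)CC1`, has not yet been measured in this assay. It differs from compound 1 in one place: tert-butoxycarbonyl in place of hydrogen on an amine nitrogen in a ring. For the measured compounds named here, with no comparable step among the measured compounds, any expectation rests on compound 1 alone and on the nature of the change. The step of a 1.4-fold higher number from compound 1 to compound 4 (0.14 log units; within the scatter) is expected to be modest, a slight rise in the number that may well stay inside the usual scatter. Compound 4 is therefore estimated at 25000 nM, with a range from 8000 nM to 80000 nM.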

Compound 4, half-maximal inhibitory concentration: 30000 nM
Beside the measured number, compound 4's estimate is 1.2-fold (0.08 log units) below it; the range from low to high includes it.
By their numbers in this assay, from the lowest: compounds 1, 4 and 2 (each within the scatter of the next, the first and the last beyond it); then compound 3.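

In this assay, among the compounds shown here, the step from hydrogen to tert-butoxycarbonyl on the amine nitrogen of the six-membered ring gives the first direct single-place comparison in this set: a 1.7-fold higher number from compound 1 to compound 4 (0.22 log units; within the scatter). Compound 4 therefore cannot be told apart from compound 1 in this assay, and this nitrogen can carry tert-butoxycarbonyl instead of hydrogen without a shift that exceeds the usual scatter. No measurement shown here accounts for how small this step is.

From the compounds shown here alone, it remains open whether other groups on this same nitrogen, such as methyl, acetyl or a longer alkyl chain, would also stay within the scatter, or whether a chain ending in a carboxylic acid or a further amine would move the number beyond it. The effect of a fluorine or a methoxy group elsewhere on the core of compound 1 is also unknown, since this single step speaks only to the ring nitrogen.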